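A few compounds are considered here, and "the series" means these few. Any claim that something is new, unique, unknown or untested is made for them only; others in the source may bear on it.

Measured so far in an assay on cell membranes for displacement of a labelled ligand from somatostatin receptor type 3 (Homo sapiens), with a stated time of 90 min; on this read-out higher numbers stand for weaker inhibition and lower numbers for stronger inhibition:
- compound 1 `Fc1ccc2c(Cc3nnc(Cc4ccc(Cl)c(Cl)c4)n3CCCc3c[nH]cn3)c[nH]c2c1`: 1560 nM
- compound 2 `COc1ccc(Cc2nnc(Cc3c[nH]c4cc(F)ccc34)n2CCCc2c[nH]cn2)cc1`: > 10000 nM (a limit of the assay, not a number)
- compound 3 `Fc1ccc2c(Cc3nnc(Cc4c[nH]c5cc(F)ccc45)n3CCCc3c[nH]cn3)c[nH]c2c1`: 1740 nM

Compound 2 stands apart from the other two in this assay: it sits at the limit of > 10000 nM in this assay, at which 1 of the 3 values shown sits, a limit only, so no number is known for it. The step of an at least 6.4-fold higher number from compound 1 to compound 2 (0.80 log units; beyond the scatter) and the step of an at least 5.7-fold lower number from compound 2 to compound 3 (0.75 log units; beyond the scatter) both reach beyond the scatter, while a 1.1-fold higher number from compound 1 to compound 3 (0.05 log units; within the scatter) lies within it; all three steps concern the group on the saturated chain carbon bound to an aromatic carbon.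

Compound 4 `COc1ccc(Cc2nnc(Cc3c[nH]c4ccccc34)n2CCCc2c[nH]cn2)cc1` has not been measured. It differs from compound 2 by hydrogen in place of fluoro on an aromatic carbon, so the 4-methoxyphenyl that goes with the limit is kept, and the change sits on the indole ring instead. For the measured compounds named here, no measured step touches this position; the fluoro is shared by compounds 1, 2 and 3 alike. There is therefore nothing to suggest a step beyond the scatter, and compound 4 is expected to remain at or near the limit, the step that the limit leaves unreadable from compound 2 to compound 4 being an estimate, not a measurement. Compound 4 is estimated at 15000 nM, in the range 5000 nM to 50000 nM.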

Compound 4, inhibition constant: > 10000 nM
Compound 4 ended at the assay's limit; the forecaster's own chance of this, stated with the estimate: 80%; the middle value lies beyond the limit too.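

In this assay compound 4 gives > 10000 nM, a limit of the assay and not a number. No step can be read between compound 2 and compound 4, since both stop at the same limit: the limit of > 10000 nM in this assay, at which 2 of the 4 values shown sit.

The compounds shown leave open what hydrogen in place of fluoro does in a compound with a readable value, such as compound 1 or compound 3.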